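This account rests on a few compounds, and the source may have more. Where it says the series, first, only, none or still open, it means among the compounds named here.

Working notes on the series. The shared core is common to compound 1 `Cc1cn2c(-c3cn[nH]c3)cnc2c(Nc2cc(Cn3cccc(C)c3=O)ns2)n1`, compound 2 `Cc1cn2c(-c3cn[nH]c3)cnc2c(Nc2cc(Cc3nccs3)ns2)n1`, compound 3 `Cc1cccc(Cc2cc(Nc3nc(C)cn4c(-c5cn[nH]c5)cnc34)sn2)n1` and compound 4 `Cc1cn2c(-c3cn[nH]c3)cnc2c(Nc2cc(Cc3cccc(C(=O)N4CCCCC4)n3)ns2)n1`. In an ADME assay on the whole organism for pharmacokinetics, with Rattus norvegicus as the target, with a stated time of 6 h, at a dose of 10 mg/kg by the oral route (a higher number here means more compound in the circulation at the dose given, a lower number less compound in the circulation), compound 2 gives 1540 ng.h/mL and compound 3 gives 3100 ng.h/mL; in this assay compound 1 gives "not determined" (no result reported), so no number is in hand for it. Among the compounds with values here, the one measured step, a 2.0-fold higher number from compound 2 to compound 3 (0.30 log units; within the scatter), is within the scatter, so compound 3 sits at the higher of the two numbers without standing apart from compound 2. Compound 4 differs from compound 3 by (piperidin-1-yl)carbonyl in place of methyl on an aromatic carbon. Within the data shown here, no measured step touches this position or this kind of group; the only step in hand, a 2.0-fold higher number from compound 2 to compound 3 (0.30 log units; within the scatter), exchanges one ring for another on the saturated chain carbon and cannot be carried over. With nothing to anchor a direction, the expected step of a 1.7-fold lower number from compound 3 to compound 4 (0.24 log units; within the scatter) is put somewhat downward but with a wide range that covers no change. Compound 4 is estimated at 1800 ng.h/mL in this assay, expected between 450 ng.h/mL and 6000 ng.h/mL.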

Compound 4, area under the concentration-time curve: 50 ng.h/mL
For compound 4 the middle estimate is 36-fold (1.56 log units) above the measured one; the whole stated range lies above it.
By their numbers in this assay, from the lowest: compound 4; then compounds 2 and 3 (each within the scatter of the next).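

Placing (piperidin-1-yl)carbonyl instead of methyl on this aromatic carbon, next to the ring nitrogen and meta to a large group, gives a 62-fold lower number from compound 3 to compound 4 (1.79 log units; beyond the scatter) in this assay. Within the data shown here, the exchange of rings on the saturated chain carbon, a 2.0-fold higher number from compound 2 to compound 3 (0.30 log units; within the scatter), stayed within the scatter, so this is the first step to go beyond it, and it shows that the number in this assay can respond strongly to the group at this position. No evidence in hand bears on the reason for the drop.

As far as these compounds go, whether the drop goes with the carbonyl, the piperidine ring or the whole group stays open. A primary amide, a carboxylic acid or a plain amine at this position would separate these readings.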